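A few compounds are considered here, and "the series" means these few. Any claim that something is new, unique, unknown or untested is made for them only; others in the source may bear on it.

Series notes, cytotoxicity branch.

Two members of the series have been run in an ADME assay on WI-38 cells (Homo sapiens) for cytotoxicity, read by sulforhodamine B assay, with a stated time of 24 h; on this read-out higher numbers stand for weaker inhibition and lower numbers for stronger inhibition. Compound 1 `O=C1Nc2ccc(S(=O)(=O)N3CCOCC3)cc2/C1=N/c1ccc(C(=O)O)cc1` gives 313000 nM in this assay, the highest of the two numbers to hand. Compound 2 `O=C1Nc2ccc(S(=O)(=O)N3CCOCC3)cc2/C1=N/c1ccc(/N=C2\C(=O)Nc3ccc(S(=O)(=O)N4CCOCC4)cc32)cc1` gives 203000 nM in this assay; its number and that of compound 1 sit within the scatter of each other, so the two are read as alike and nothing is made of their order.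

The next point to be run is compound 3 `CC(=O)N/N=C1\C(=O)Nc2ccc(S(=O)(=O)N3CCOCC3)cc21`, which differs from compound 1 in one place: acetamido in place of 4-carboxyphenyl on a double-bonded nitrogen. Among the compounds with values here, both measured members leave the shared core untouched, and there is no measured step between members that differ in one place, so the size of this change can only be anticipated from how flat the two numbers already are.

For compound 3 the step of a 1.3-fold lower number from compound 1 to compound 3 (0.10 log units; within the scatter) in this assay is expected to stay within the scatter, with no clear direction. Compound 3 is accordingly estimated at 250000 nM in this assay, with a range from 100000 nM to 600000 nM, pending the measurement.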

Compound 3, half-maximal inhibitory concentration: 325000 nM
Beside the measured number, compound 3's estimate is 1.3-fold (0.11 log units) below it, and the stated range covers the measured number.
By their numbers in this assay, from the lowest: compounds 2, 1 and 3 (each within the scatter of the next).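

In this assay, within the data shown here, acetamido in place of 4-carboxyphenyl on a double-bonded nitrogen gives a 1.0-fold higher number from compound 1 to compound 3 (0.02 log units; within the scatter), the first step that isolates one place. Among these compounds, at this position, then, the substituent can go from 9 heavy atoms to 4 and give up its six-membered aromatic ring of carbon only without a step beyond the scatter, something the earlier pair, with no single-place step between them, could not show. No evidence in hand offers an explanation for this flat result.

Still open, going by these compounds, is whether this flatness extends to other groups on the double-bonded nitrogen, such as a primary amine, a longer alkyl chain or a hydroxyl group, and whether any of them gives a step beyond the scatter. Also open, on these data alone, is how the read-out responds to a change elsewhere on the shared core, since all three compounds keep that core as it stands.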